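The compounds below may be only part of what the source reports. "The series", "measured", "known", "first", "only" and "open" are said of these compounds alone.

Measured compounds:
Compound 1, `CC(C(=O)NCc1ccc(C(F)(F)F)cc1N1CCN(c2ccccc2)CC1)c1ccc(NS(C)(=O)=O)c(F)c1`, gives 2 nM.
Compound 2, `CC(C(=O)NCc1ccc(C(F)(F)F)cc1OCc1ccc(F)cc1)c1ccc(NS(C)(=O)=O)c(F)c1`, gives 0.5 nM.
Compound 3, `CCCCCCSc1cc(C(F)(F)F)ccc1CNC(=O)C(C)c1ccc(NS(C)(=O)=O)c(F)c1`, gives 1.8 nM.

In an assay on CHO cells for antagonist activity at transient receptor potential cation channel subfamily V member 1 (Homo sapiens), read by FLIPR (a lower number here means a stronger inhibitor, a higher number a weaker inhibitor), compound 3 stands second highest of the three numbers; its nearest neighbour is compound 1, the step of a 1.1-fold lower number from compound 1 to compound 3 (0.05 log units; within the scatter) lying within the scatter, while the step of a 3.6-fold higher number from compound 2 to compound 3 (0.56 log units; beyond the scatter) is beyond it. Compound 4, `CC(C(=O)NCc1ccc(C(F)(F)F)cc1SC1CCCC1)c1ccc(NS(C)(=O)=O)c(F)c1`, differs from compound 3 by cyclopentyl in place of hexyl on a sulfur. Within the data shown here, no measured step changes the group on the sulfur itself; the two steps that touch this position, a 1.1-fold lower number from compound 1 to compound 3 (0.05 log units; within the scatter) and a 3.6-fold higher number from compound 2 to compound 3 (0.56 log units; beyond the scatter), replace the whole substituent on the aromatic carbon and are small or modest. On that basis the step of a 1.1-fold higher number from compound 3 to compound 4 (0.05 log units; within the scatter) is expected to stay within the scatter, and compound 4 is estimated at 2 nM, with a range from 0.7 nM to 6 nM.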

Compound 4, inhibition constant: 0.3 nM
Beside the measured number, compound 4's estimate is 6.7-fold (0.82 log units) above it, outside the stated range (below it).
By their numbers in this assay, from the lowest: compounds 4 and 2 (each within the scatter of the next); then compounds 3 and 1 (each within the scatter of the next).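

In this assay, the group on the sulfur itself proves to matter: cyclopentyl in place of hexyl gives (a 6.0-fold lower number from compound 3 to compound 4 (0.78 log units; beyond the scatter)). With cyclopentylsulfanyl on the aromatic carbon, the result stays within the scatter of the (4-fluorobenzyl)oxy compound (a 1.7-fold lower number from compound 2 to compound 4 (0.22 log units; within the scatter)) and moves clear of the 4-phenylpiperazin-1-yl compound (a 6.7-fold lower number from compound 1 to compound 4 (0.82 log units; beyond the scatter)). No supporting evidence accounts for these differences.

This one step introduces a ring and changes the carbon count together. The compounds shown leave open whether a pentyl chain or a cyclohexyl ring on the sulfur would behave like cyclopentyl or like hexyl.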